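Selenium-bearing quinazoline series: pentyl on selenium, cytotoxicity notes

A few compounds are considered here, and "the series" means these few. Any claim that something is new, unique, unknown or untested is made for them only; others in the source may bear on it.

Measured compounds in a functional assay on CCRF-CEM cells (Homo sapiens) for cytotoxicity, read by MTT assay, with a stated time of 72 h; on this read-out lower numbers stand for higher toxicity in this test and higher numbers for lower toxicity in this test:
- compound 1, `CCCCC[Se]c1nc(NCc2ccc(SC)cc2)c2ccccc2n1`: > 100000 nM
- compound 2, `CSc1ccc(CNc2nc([SeH])nc3ccccc23)cc1`: > 100000 nM
- compound 3, `Nc1nc([SeH])nc2ccccc12`: 79100 nM

In this assay compound 1 gives > 100000 nM, which is a limit of the assay and not a number. Compound 2 likewise gives > 100000 nM, again a limit of the assay. For the measured compounds named here, compound 3 is the only compound of the three with a number, giving 79100 nM. The change from compound 2 to compound 1 is pentyl in place of hydrogen on a selenium, and the step that the two limits leave unreadable from compound 2 to compound 1 cannot be read because of the limit of > 100000 nM in this assay, at which 2 of the 3 values shown sit. How the core of compound 3 differs from that of compound 2 is not broken down here.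

Compound 4, `CCCCC[Se]c1nc(N)c2ccccc2n1`, is not yet measured in this assay. It differs from compound 3 by pentyl in place of hydrogen on a selenium, the same change as from compound 2 to compound 1, and the place is the same: on a selenium whose other neighbours are an aromatic carbon. The earlier step gives no readable size, so the expectation for compound 4 rests on compound 3 and its value 79100 nM, taken as the starting point, with the step from compound 3 to compound 4 expected to be a 1.3-fold higher number from compound 3 to compound 4 (0.10 log units; within the scatter), near the scatter of this assay. Compound 4 is therefore expected to give about 100000 nM, between 30000 nM and 300000 nM, with a fair chance that only a limit is reported.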

Compound 4, concentration lethal to 50% of the cells: > 100000 nM
Compound 4 was reported as a limit; the forecaster's own chance of this, stated with the estimate: 50%; the middle value lies on the limit itself.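

In this assay, pentyl in place of hydrogen on a selenium gives an at least 1.2-fold higher number from compound 3 to compound 4 (0.10 log units; that floor lies within the scatter), a floor that does not separate the two compounds and leaves the true size of the step unknown. Compound 4 gives > 100000 nM, which is a limit of the assay and not a number. The two cases of this change show no disagreement between the core of compound 2 and the core of compound 3, but they do not show that the change has the same size on both, and neither step has a measurable size because of where the values sit: the limit of > 100000 nM in this assay, at which 3 of the 4 values shown sit.

On these data alone, whether a methyl group, a longer chain such as decyl, or a chain ending in an amine or a carboxylic acid on the same selenium would give a number rather than a limit on either core remains open. Also open, as far as these compounds go, is whether pentyl on a selenium changes the read-out at all on the core of compound 3, and whether any such change would carry over to the core of compound 2.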